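Working notes: from 3,4-dichlorophenyl to 3,5-dichlorophenyl

The compounds below may be only part of what the source reports. "The series", "measured", "known", "first", "only" and "open" are said of these compounds alone.

In a functional assay on HepG2 cells (Homo sapiens) for antiproliferative activity, read by MTT assay, with a stated time of 48 h (on this read-out higher numbers stand for weaker inhibition and lower numbers for stronger inhibition), compound 2 `O=C(/C=C/c1ccccc1)Nc1cc2c(Nc3ccc(Cl)c(Cl)c3)ncnc2s1` gives 30100 nM. Compound 1 `O=C(/C=C/c1ccc(O)cc1)Nc1cc2c(Nc3ccc(Cl)c(Cl)c3)ncnc2s1` gives 42900 nM, level with compound 2 within the scatter. Compound 3 `O=C(/C=C/c1ccccc1)Nc1cc2ncnc(Nc3ccc(F)c(Cl)c3)c2s1` gives 10600 nM, a lower number than compound 2 by more than the scatter. Compound 2 therefore sits with compound 1 at the weaker end of this small set. Among the measured compounds shown here, no single-place step connects compound 3 with compound 2, so its value offers only a rough sense of the spread.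

The next compound to be read is compound 4 `O=C(/C=C/c1ccccc1)Nc1cc2c(Nc3cc(Cl)cc(Cl)c3)ncnc2s1`. The change is 3,5-dichlorophenyl in place of 3,4-dichlorophenyl on a nitrogen on an aromatic ring. The two have the same atoms, joined differently.

For the measured compounds named here, only one measured step is available, a 1.4-fold lower number from compound 1 to compound 2 (0.15 log units; within the scatter). It is hydrogen in place of hydroxy on an aromatic carbon, at another place in the molecule, and it stays within the scatter. Going by the values given here, no measured step shifts a chlorine, so the evidence is indirect and no direction can be argued from it. No change beyond the scatter is expected in this assay, and the estimate is a 1.1-fold lower number from compound 2 to compound 4 (0.03 log units; within the scatter). For compound 4 the expected value is 28000 nM, with an estimated range of 11000 nM to 60000 nM.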

Compound 4, half-maximal inhibitory concentration: 21800 nM
Estimate against measurement, compound 4: 1.3-fold (0.11 log units) above, within the range that was stated.
By their numbers in this assay, from the lowest: compound 3; then compounds 4, 2 and 1 (each within the scatter of the next).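

Among the compounds shown here, the exchange of 3,4-dichlorophenyl for 3,5-dichlorophenyl on a nitrogen on an aromatic ring gives the first measured step at this position: in this assay there is a 1.4-fold lower number from compound 2 to compound 4 (0.14 log units; within the scatter). The earlier step concerned hydrogen in place of hydroxy at another place in the molecule, so it said nothing about this group, whereas this pair shows that, with the same atoms in the group and the rest of the molecule unchanged, this rearrangement of the two chlorines leaves compound 4 level with compound 2 within the scatter. Nothing measured on these two groups is at hand to interpret the step, so the result stands as an observation for this one pair in this one assay.

Going by these compounds, whether a group of another kind on this nitrogen, such as 3,5-difluorophenyl or 3,5-dimethoxyphenyl, would move the number beyond the scatter remains open. For the compounds shown here, also open are whether the same exchange of chlorines reads alike when hydroxy is present on the other aromatic ring, as in compound 1, and how compound 3 relates to compound 4, since no single-place step connects them.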